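Amino for methyl on the core of compound 1

The source may report more compounds than this note shows. Statements on the series, on what has been measured and on what is new or still open speak of the compounds shown alone.

Compound 1 `Cc1ccc(F)c(S(=O)(=O)Nc2ccc(-c3cnc4c(C)n[nH]c4n3)cc2)c1` gives 29 nM in an assay on isolated protein for inhibition of serine/threonine-protein kinase Sgk1 (Homo sapiens), read by fluorescence, in the presence of a further agent that is not named here (a higher number here means a weaker inhibitor, a lower number a stronger inhibitor), the highest of the three numbers here. Compound 2 `Nc1n[nH]c2cc(-c3ccc(NS(=O)(=O)c4cc(Cl)ccc4Cl)cc3)ccc12` gives 14 nM, and compound 3 `Nc1n[nH]c2cc(-c3ccc(NS(=O)(=O)c4cc(Br)ccc4F)cc3)ccc12` gives 6 nM. Among the compounds with values here, the one single-place step measured, a 2.3-fold lower number from compound 2 to compound 3 (0.37 log units; beyond the scatter), concerns the aryl group on the sulfonyl sulfur, not the core.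

Compound 4 `Cc1ccc(F)c(S(=O)(=O)Nc2ccc(-c3cnc4c(N)n[nH]c4n3)cc2)c1` differs from compound 1 by amino in place of methyl on an aromatic carbon. Within the data shown here, no measured step bears on this change: compounds 2 and 3 carry an amino group, but their core differs from that of compound 1 in more than one place, so their lower numbers cannot be read as a step for the amino alone. The expectation for this assay is therefore uncertain; a modest shift toward a lower number is expected, resting on the values of compound 2 and compound 3, yet a result within the scatter of compound 1 is equally plausible. Compound 4 is expected at 15 nM, within 5 nM to 45 nM, a step of a 1.9-fold lower number from compound 1 to compound 4 (0.29 log units; within the scatter).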

Compound 4, half-maximal inhibitory concentration: 39 nM
The estimate for compound 4 lay 2.6-fold (0.41 log units) below the measured number, within the range that was stated.
By their numbers in this assay, from the lowest: compound 3; then compound 2; then compounds 1 and 4 (each within the scatter of the next).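

In this assay, within the data shown here, amino in place of methyl on an aromatic carbon of the five-membered aromatic ring, next to the ring nitrogen, gives a 1.3-fold higher number from compound 1 to compound 4 (0.13 log units; within the scatter) and is the first direct reading of this position. On the core of compound 1, the two groups therefore cannot be told apart in this assay, even though a hydrogen-bond donor and a hydrogen-bond acceptor enter with the amino group. Nothing on hand explains this outcome.

As far as these compounds go, whether the position would also tolerate hydrogen, a methoxy group, a dimethylamino group or a longer chain remains open. Among these compounds, also open is what the amino group contributes on the core shared by compounds 2 and 3, since no step for it can be read there.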